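Inverting One Stereocentre of Compound 2

The source may hold more compounds than are shown below. What is called first, only, known or untested is meant among the compounds shown, and "the series" means these compounds.

In a functional assay on HCT-116 cells (Homo sapiens) for inhibition, read by MTT assay, with a stated time of 72 h (on this read-out lower numbers stand for stronger inhibition and higher numbers for weaker inhibition), compound 1 `CC1=NN(c2ccccc2)C(=O)[C@]12C(=O)C=CC[C@@H]2c1cccc(C)c1` gives 5490 nM and compound 2 `CC1=NN(c2ccccc2)C(=O)[C@@]12C(=O)C=CC[C@@H]2c1ccccc1` gives 6070 nM, so the two numbers lie within the usual scatter of each other. Going by the values given here, compound 2 therefore stands level with the only other measured compound. Compound 3 `CC1=NN(c2ccccc2)C(=O)[C@]12C(=O)C=CC[C@@H]2c1ccccc1` departs from compound 2 in configuration alone: the two compounds have the same atoms and bonds and differ only in configuration as drawn: 1 of 2 stereo elements differ; a stereocentre at a saturated ring carbon is drawn R in compound 2 and S in compound 3. The two compounds have the same atoms and bonds, and a stereocentre at a saturated ring carbon is drawn R in compound 2 and S in compound 3. Among the compounds with values here, no measured pair shows what such an inversion does, so the data offer no direct guide to its size or direction. The expected step in this assay is a 1.0-fold lower number from compound 2 to compound 3 (0.01 log units; within the scatter), none beyond the scatter, and a shift either way remains possible. For compound 3 the estimated value is 6000 nM, with an expected range of 2500 nM to 15000 nM.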

Compound 3, half-maximal inhibitory concentration: 6040 nM
The estimate for compound 3 lay 1.0-fold (0.00 log units) below the measured number, and the stated range covers the measured number.
By their numbers in this assay, from the lowest: compounds 1, 3 and 2 (each within the scatter of the next).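

In this assay, the pair of compound 2 and compound 3 isolates a single stereocentre at a saturated ring carbon, drawn R in one and S in the other, and gives a 1.0-fold lower number from compound 2 to compound 3 (0.00 log units; within the scatter): the fact that compounds 2 and 3 differ only in the configuration as drawn. Going by these compounds alone, this configuration therefore makes no difference beyond the scatter in this pair, which the earlier compounds could not show. Compound 3 also allows a one-place comparison with compound 1, where hydrogen in place of methyl on an aromatic carbon gives a 1.1-fold higher number from compound 1 to compound 3 (0.04 log units; within the scatter).

The compounds shown leave open what inverting the second stereocentre would do, and whether the same inversion would have as small an effect with the methyl present. They also leave open whether an amine or a carboxylic acid on that aromatic carbon would give a number beyond the scatter.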